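The compounds below may be only part of what the source reports. "The series", "measured", "known", "first", "only" and "open" are said of these compounds alone.

Compound 1 `C=C1[C@H](C)CCC[C@]1(C)CC/C(C)=C/CC1=C(O)C(=O)C=C(N[C@@H](C(=O)O)C(C)C)C1=O` gives 3.4 ug/mL in an ADME assay on L1210 cells (Mus musculus) for cytotoxicity, with a stated time of 48 h (on this read-out lower numbers stand for stronger inhibition and higher numbers for weaker inhibition), and stands as the only numeric result in the set. Compound 2 `CC1=CCC[C@](C)(CC/C(C)=C/CC2=C(O)C(=O)C=C(N[C@@H](CO)C(=O)O)C2=O)[C@@H]1C` returns only a limit of this assay, > 10 ug/mL, not a number; (the limit of > 10 ug/mL in this assay, at which 1 of the 2 values shown sits). Compound 3 `C=C1[C@H](C)CCC[C@]1(C)CC/C(C)=C/CC1=C(O)C(=O)C=C(N[C@H](C(=O)O)C(C)C)C1=O` differs from compound 1 as follows: the two compounds have the same atoms and bonds and differ only in configuration as drawn: 1 of 4 stereo elements differ; a stereocentre at a saturated chain carbon is drawn R in compound 1 and S in compound 3. For the measured compounds named here, no step between two measured compounds exists here, so the weight of this change is untested within the set. The expected step from compound 1 to compound 3 is a 1.6-fold higher number from compound 1 to compound 3 (0.21 log units; within the scatter), a modest weakening that may not clear the scatter. Compound 3 is expected at 5.5 ug/mL, within 2.5 ug/mL to 12 ug/mL.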

Compound 3, half-maximal inhibitory concentration: 4.4 ug/mL
Compound 3: the middle estimate sits 1.3-fold (0.10 log units) above what was measured; the measured number falls inside the stated range.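

In this assay, for the compounds shown here, the first readable step is a 1.3-fold higher number from compound 1 to compound 3 (0.11 log units; within the scatter) for the switch from R to S at a saturated chain carbon. This inversion therefore stays inside the scatter and, on this read-out, does not separate the two configurations at this stereocentre.

Still open, as far as these compounds go, is whether the other stereo elements behave the same way, and whether either configuration at this carbon stays equally undifferentiated when a primary amide or a methyl ester replaces the carboxylic acid.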